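Cyclopropyl ketone series: Vero cytotoxicity, amine to imidazole

A few compounds are considered here, and "the series" means these few. Any claim that something is new, unique, unknown or untested is made for them only; others in the source may bear on it.

Measured so far:
compound 1 `CN(C)CCCNc1ccc(C(=O)C2CC2c2ccc(Cl)cc2)cc1` — 15.8 ug/mL
compound 2 `COc1ccc(C2CC2C(=O)c2ccc(N3CCN(C)CC3)cc2)cc1OC` — 77.8 ug/mL

In an ADME assay on Vero cells (Chlorocebus sabaeus) for cytotoxicity, with a stated time of 72 h (a higher number here means that more compound is tolerated, a lower number that less compound is tolerated), compound 1 gives 15.8 ug/mL, the lower of the two numbers on hand. Compound 2 gives 77.8 ug/mL, a higher number, and the gap between compound 2 and compound 1 lies beyond the scatter. Among the measured compounds shown here, no pair of compounds differing in one place has yet been measured, so no single step is known in this assay.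

Compound 3 `O=C(c1ccc(NCCn2ccnc2)cc1)C1CC1c1ccc(Cl)cc1` is not yet measured. It differs from compound 1 as follows: 1H-imidazol-1-yl in place of (dimethylamino)methyl on a saturated chain carbon, two bonds along the chain from a nitrogen on an aromatic ring. For the measured compounds named here, with no measured step of this kind available, a modest upward step is expected from compound 1 to compound 3, a 1.6-fold higher number from compound 1 to compound 3 (0.20 log units; within the scatter), though a result within the scatter of compound 1 would not surprise. For compound 3 in this assay the expected value is 25 ug/mL, with a range from 10 ug/mL to 70 ug/mL.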

Compound 3, half-maximal cytotoxic concentration: 243 ug/mL
Beside the measured number, compound 3's estimate is 9.7-fold (0.99 log units) below it, outside the stated range (above it).
By their numbers in this assay, from the lowest: compound 1; then compound 2; then compound 3.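

In this assay, 1H-imidazol-1-yl in place of (dimethylamino)methyl, on a saturated chain carbon, two bonds along the chain from a nitrogen on an aromatic ring, gives a 15-fold higher number from compound 1 to compound 3 (1.19 log units; beyond the scatter), the first single step known in this series. With the rest of compound 1 unchanged, the outer end of this chain alone moves the number well beyond the scatter, so this position is not silent in this assay. Nothing on hand bears on the reason for the step.

Cut one bond further out, the same change reads 3-(dimethylamino)propyl to 2-(1H-imidazol-1-yl)ethyl, so the end group and the chain change together in this one step. A 2-(dimethylamino)ethyl or a 3-(1H-imidazol-1-yl)propyl chain would be needed to separate the two, and a pyrazole or a morpholine at the chain end would show whether the step is particular to the imidazole.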